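Trading Phenyl for Isopropyl in Compound 2

The source may report more compounds than this note shows. Statements on the series, on what has been measured and on what is new or still open speak of the compounds shown alone.

Within the data shown here, in a functional assay on PC-3 cells (Homo sapiens) for antiproliferative activity, read by MTT assay, with a stated time of 48 h (on this read-out lower numbers stand for stronger inhibition of growth and higher numbers for weaker inhibition of growth), compound 2 `Cc1ccc(-c2cnc(N(Cc3ccccc3)Cc3ccc(C(=O)NO)cc3)s2)cc1` gives 10400 nM, the higher of the two numbers measured so far. Among the measured compounds shown here, its only measured neighbour, compound 1 `CCCCCN(Cc1ccc(C(=O)NO)cc1)c1ncc(-c2ccc(C)cc2)s1`, gives 5060 nM, so compound 2 is the weaker growth inhibitor of the pair. Compound 3 `Cc1ccc(-c2cnc(N(Cc3ccc(C(=O)NO)cc3)CC(C)C)s2)cc1` differs from compound 2 in one place: isopropyl in place of phenyl on a saturated chain carbon bound to a nitrogen on an aromatic ring. The same difference, cut one bond further out, reads benzyl to isobutyl. For the measured compounds named here, one measured step bears on this change: a 2.1-fold higher number from compound 1 to compound 2 (0.31 log units; beyond the scatter), a modest move that came with phenyl in place of butyl. Compound 3 also loses that phenyl and carries an open chain, as compound 1 does, so a similarly modest move towards a lower number seems likely. The expected step is a 1.6-fold lower number from compound 2 to compound 3 (0.20 log units; within the scatter). For compound 3 the estimate is 6500 nM, with an expected range from 2800 nM to 14000 nM.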

Compound 3, concentration for 50% growth inhibition: 9340 nM
For compound 3 the middle estimate is 1.4-fold (0.16 log units) below the measured one; the range from low to high includes it.
By their numbers in this assay, from the lowest: compounds 1, 3 and 2 (each within the scatter of the next, the first and the last beyond it).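

In this assay, isopropyl in place of phenyl at this position gives a 1.1-fold lower number from compound 2 to compound 3 (0.05 log units; within the scatter), so a group with no ring and fewer carbons reads the same as phenyl here within the scatter. Isopropyl in place of butyl gives a 1.8-fold higher number from compound 1 to compound 3 (0.27 log units; within the scatter), so compound 3 cannot be told apart from compound 1 either, and the gap between compound 1 and compound 2 does not extend into a clear divide between open chains and a ring-bearing group. Nothing at hand explains these results.

From the compounds shown here alone, all three groups at this position contain carbon only, so what an amine or a carboxylic acid on the chain would do remains open. Going by these compounds, whether a longer chain would separate clearly from these compounds also remains open.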